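Cyclopropyl for difluorophenyl on the alkyne of a uracil diol

The source may report more compounds than this note shows. Statements on the series, on what has been measured and on what is new or still open speak of the compounds shown alone.

Measured compounds:
compound 1 `CCCCCCCCC#Cc1cn(CCC(COC(C)=O)COC(C)=O)c(=O)n(C(=O)c2ccccc2)c1=O`, 65800 nM
compound 2 `O=c1[nH]c(=O)n(CCC(CO)CO)cc1C#Cc1cc(F)cc(F)c1`, > 100000 nM

In a functional assay on SW-620 cells (Homo sapiens) for antiproliferative activity, read by MTT assay, with a stated time of 72 h (a lower number here means a stronger inhibitor, a higher number a weaker inhibitor), compound 1 gives 65800 nM. For compound 2 the result in this assay is only a limit, > 100000 nM; (the limit of > 100000 nM in this assay, at which 1 of the 2 values shown sits). Compound 3 `O=c1[nH]c(=O)n(CCC(CO)CO)cc1C#CC1CC1` differs from compound 2 by cyclopropyl in place of 3,5-difluorophenyl on a triple-bonded carbon. Among the measured compounds shown here, no measured pair shows a step of this kind, so the size of the change in this assay is unknown; given that compound 2 sits at the limit > 100000 nM, compound 3 is expected to remain near that limit, with the step that the limit leaves unreadable from compound 2 to compound 3 estimated as none beyond the scatter. Compound 3 is therefore estimated at 120000 nM, between 40000 nM and 400000 nM.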

Compound 3, half-maximal inhibitory concentration: > 100000 nM
Compound 3 ended at the assay's limit; the forecaster's own chance of this, stated with the estimate: 75%; the middle value lies beyond the limit too.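

In this assay, compound 2 and compound 3 both give only a limit, so no step can be read between them: the limit of > 100000 nM in this assay, at which 2 of the 3 values shown sit.

The compounds shown leave open what the actual potency of either compound is, and whether cyclopropyl in place of 3,5-difluorophenyl changes it at all.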